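From Allyl to 2-Aminocyclohexyl on the Sulfur

The compounds below may be only part of what the source reports. "The series", "measured", "known", "first", "only" and "open" are said of these compounds alone.

In a functional assay on HT cells (Homo sapiens) for antiproliferative activity, read by fluorescence, with a stated time of 72 h (a lower number here means a stronger inhibitor of growth, a higher number a weaker inhibitor of growth), compound 1 `CC(C)c1n[nH]c2c(NCc3ccc(-c4ccccn4)cc3)nc(SCCNC(=N)N)nc12` gives 390 nM, compound 2 `CC(C)c1n[nH]c2c(NCc3ccc(-c4ccccn4)cc3)nc(S)nc12` gives 2760 nM, and compound 3 `C=CCSc1nc(NCc2ccc(-c3ccccn3)cc2)c2[nH]nc(C(C)C)c2n1` gives 1010 nM. Compound 3 thus holds the middle of the three numbers, beyond the scatter from both of the others. Compound 4 `CC(C)c1n[nH]c2c(NCc3ccc(-c4ccccn4)cc3)nc(SC3CCCCC3N)nc12` departs from compound 3 at one place: 2-aminocyclohexyl in place of allyl on a sulfur, with 2-aminocyclohexyl in place of allyl on a sulfur. Among the measured compounds shown here, three measured steps bear on this change. Allyl in place of hydrogen gave a 2.7-fold lower number from compound 2 to compound 3 (0.44 log units; beyond the scatter), and the nitrogen-bearing chain of compound 1 compares with allyl through a 2.6-fold higher number from compound 1 to compound 3 (0.41 log units; beyond the scatter). The widest measured step is a 7.1-fold higher number from compound 1 to compound 2 (0.85 log units; beyond the scatter). For the measured compounds named here, compound 1 is the only measured compound with nitrogen in the group on sulfur, and no measured compound has a ring there, so the comparison is loose. A modest move towards a lower number in this assay is expected, similar in size to the step between compound 1 and compound 3. The expected change is a 2.5-fold lower number from compound 3 to compound 4 (0.40 log units; beyond the scatter). For compound 4 the estimated value is 400 nM, with an expected range of 120 nM to 1300 nM.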

Compound 4, concentration for 50% growth inhibition: 139 nM
The estimate for compound 4 lay 2.9-fold (0.46 log units) above the measured number; the range from low to high includes it.
By their numbers in this assay, from the lowest: compound 4; then compound 1; then compound 3; then compound 2.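

Among the compounds shown here, putting 2-aminocyclohexyl on the sulfur in place of allyl gives a 7.3-fold lower number from compound 3 to compound 4 (0.86 log units; beyond the scatter) in this assay, and in place of hydrogen it gives a 20-fold lower number from compound 2 to compound 4 (1.30 log units; beyond the scatter), the one large step in the set. The ring group also goes past the nitrogen-bearing chain on the sulfur, with a 2.8-fold lower number from compound 1 to compound 4 (0.45 log units; beyond the scatter), so the lowest number of the four now belongs to a group with a ring, and both groups carrying nitrogen stand below allyl. Nothing at hand explains why the number falls with this change. The compounds shown do not separate the ring from the amine: a plain cyclohexyl on the sulfur, or a 2-aminoethyl chain, would show which of the two goes with the lower number. They also leave open whether 3-aminocyclohexyl or 4-aminocyclohexyl would do the same.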